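The compounds below may be only part of what the source reports. "The series", "measured", "known", "first", "only" and "open" are said of these compounds alone.

Compound 1 `CCn1c(C(=O)NCC(=O)OC)ccc1C(CC)(CC)c1ccc(OCS(=O)(=O)c2ccccc2)c(C)c1`: 20000 nM
Compound 2 `CCn1c(C(=O)N[C@@H](CC(=O)OC)C(=O)OC)ccc1C(CC)(CC)c1ccc(OCS(=O)(=O)c2ccccc2)c(C)c1`: > 50000 nM

These values come from a functional assay on BXPC-3 cells (Homo sapiens) for antiproliferative activity, read by MTT assay, with a stated time of 24 h; a lower number here means a stronger inhibitor, a higher number a weaker inhibitor. Compound 2 gives > 50000 nM, which is a limit of the assay and not a number. Compound 3 `CCn1c(C(=O)N[C@@H](C)CO)ccc1C(CC)(CC)c1ccc(OCS(=O)(=O)c2ccccc2)c(C)c1` is not yet measured. Its change from compound 2 is 1-(hydroxymethyl)ethyl in place of 1,2-bis(methoxycarbonyl)ethyl on an amide-type nitrogen. Within the data shown here, only one measured step bears on this: an at least 2.5-fold higher number from compound 1 to compound 2 (0.39 log units; beyond the scatter), seen when (methoxycarbonyl)methyl replaced hydrogen. Among the measured compounds shown here, removing that branch might partly reverse this step, though the new group differs from the one in compound 1. A modest fall in this assay is therefore expected, with an estimated step of an at least 2.2-fold lower number from compound 2 to compound 3 (0.35 log units; beyond the scatter). For compound 3 the estimate is 22000 nM, with an expected range of 8000 nM to 50000 nM.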

Compound 3, half-maximal inhibitory concentration: 15300 nM
Beside the measured number, compound 3's estimate is 1.4-fold (0.16 log units) above it; low and high end bracket the measured number.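

Putting 1-(hydroxymethyl)ethyl in place of 1,2-bis(methoxycarbonyl)ethyl on the amide-type nitrogen gives an at least 3.2-fold lower number from compound 2 to compound 3 (0.51 log units; beyond the scatter), so a group with no ester can restore the number lost in compound 2. The value of compound 2 is a limit of the assay and not a number: the limit of > 50000 nM in this assay, at which 1 of the 3 values shown sits. Compared with the (methoxycarbonyl)methyl group of compound 1, the same change gives a 1.3-fold lower number from compound 1 to compound 3 (0.12 log units; within the scatter), so these two side chains cannot be told apart here. Still open, from the compounds shown here alone, is whether a carboxylic acid or an amine on this chain would shift the number beyond the scatter, and what the opposite stereocentre in 1-(hydroxymethyl)ethyl would do.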